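The source may hold more compounds than are shown below. What is called first, only, known or untested is meant among the compounds shown, and "the series" means these compounds.

Compounds measured in an assay on CHO cells for displacement of a labelled ligand from Orexin receptor type 2 (Homo sapiens), read by scintillation counting, with a stated time of 3 h; a lower number here means a stronger inhibitor, a higher number a weaker inhibitor:

- compound 1, `COc1ccc(CNC(=O)c2cc(-c3cncc(C)c3)ncc2-c2cncc(F)c2)nc1OC`, gives 5.2 nM
- compound 2, `COc1ccc(CNC(=O)c2cc(-c3cncc(C)c3)ncc2-c2cnccn2)nc1OC`, gives 7.6 nM
- compound 3, `COc1ccc(CNC(=O)c2cc(-c3cncc(C)c3)ccc2-c2ccccc2)nc1OC`, gives 0.3 nM

Among these three numbers compound 2 has the highest, that is, it is the weakest binder of the set. Its nearest neighbour is compound 1, which differs only in the ring group on the shared core; the step of a 1.5-fold higher number from compound 1 to compound 2 (0.16 log units; within the scatter) is within the usual scatter, so the two cannot really be told apart. Among the compounds with values here, compound 3 is further away, and it differs from compound 2 in two places at once, so its value shows only that much lower numbers are reachable.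

Compound 4, `COc1ccc(CNC(=O)c2cc(-c3cncc(C)c3)ncc2-c2ccccc2F)nc1OC`, has not been measured yet. It is compound 2 with 2-fluorophenyl in place of pyrazin-2-yl on an aromatic carbon. Within the data shown here, the only measured step that touches this position is the one from compound 1 to compound 2, and it was small. Among the measured compounds shown here, no measured step swaps a nitrogen-containing ring for a carbon-only ring on this core, so there is no direct guide. The all-carbon ring in compound 3 goes with a low number, but its core is also different, so only a modest move is expected in this assay.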

Compound 4, inhibition constant: 1.4 nM
Estimate against measurement, compound 4: 2.1-fold (0.33 log units) above; the range from low to high includes it.
By their numbers in this assay, from the lowest: compound 3; then compound 4; then compounds 1 and 2 (each within the scatter of the next).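

Placing 2-fluorophenyl on this aromatic carbon gives a 5.4-fold lower number from compound 2 to compound 4 (0.73 log units; beyond the scatter) in this assay and so shows that this position does respond to the group it carries, which the earlier swap between two nitrogen-containing rings could not show. The second comparison agrees, with a 3.7-fold lower number from compound 1 to compound 4 (0.57 log units; beyond the scatter) in this assay and so, on this shared core, the ring of carbon only with its fluorine gives a lower number than either ring containing nitrogen, and no compound shown here goes against this. Nothing measured here explains why the number falls with this change.

The step also changes two things at once, since the ring nitrogens leave and a fluorine enters, so the compounds shown cannot say which of the two matters, or whether both do. From the compounds shown here alone, it also remains open how far the trend reaches, for example how this position would respond to an aromatic ring carrying an amine or a carboxylic acid, or to a longer chain in place of a ring.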